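This account rests on a few compounds, and the source may have more. Where it says the series, first, only, none or still open, it means among the compounds named here.

Measured so far:
compound 1 `CC(C)(C)C1=NN(c2ccc(Br)cc2)C(c2ccc(O)cc2)C1`: 11400 nM
compound 2 `CC(C)(C)C1=NN(c2ccc(Cl)cc2Cl)C(c2ccc(O)cc2)C1`: "not determined" (no result reported)
compound 3 `Cc1ccc(N2N=C(C(C)(C)C)CC2c2ccc(O)cc2)c(C)c1`: "not determined" (no result reported)

Three compounds built on the shared core were examined in an assay on isolated protein for inhibition of protein kinase C zeta type (Homo sapiens), with a stated time of 4 min; on this read-out higher numbers stand for weaker inhibition and lower numbers for stronger inhibition. Only compound 1 gives a number there, 11400 nM. Compound 2 stands as "not determined" (no result reported), and compound 3 likewise stands as "not determined" (no result reported); it is one of two entries in the set for which no result was reported. For the measured compounds named here, compound 3 therefore cannot be placed on the scale at all, and no step between measured compounds is available in this set.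

The next compound, compound 4 `CC(C)(C)C1=NN(c2ccc(F)c(Cl)c2)C(c2ccc(O)cc2)C1`, is related to compound 3 by a change on the aryl group at the ring nitrogen: 3-chloro-4-fluorophenyl in place of 2,4-dimethylphenyl on an amine nitrogen in a ring. Since compound 3 carries no number, no direction or size of step from compound 3 to compound 4 can be stated in this assay. Going by the values given here, the only anchor is compound 1, whose aryl group on the same nitrogen also carries a halogen, with 11400 nM. Compound 4 is accordingly expected to come out in the same weak region, and its estimated value is 12000 nM, with a range from 3000 nM to 50000 nM.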

Compound 4, half-maximal inhibitory concentration: 900 nM
Estimate against measurement, compound 4: 13-fold (1.12 log units) above; measured number below the stated range.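

In this assay, the aryl group on the amine nitrogen in a ring can shift the read-out by a wide margin: 3-chloro-4-fluorophenyl in place of 4-bromophenyl gives a 13-fold lower number from compound 1 to compound 4 (1.10 log units; beyond the scatter) with the rest of the shared core unchanged. Carrying halogen on this aryl group therefore does not by itself fix the value, as two halogen-bearing groups at this position stand well apart, beyond the usual scatter. The steps from compound 2 and compound 3 cannot be read, and no measurement on hand accounts for the change.

From the compounds shown here alone, whether the chlorine, the fluorine or their arrangement on the 3-chloro-4-fluorophenyl group carries the step stays open, as does how this nitrogen would respond to an aryl group bearing a methoxy group or an amine. The compounds shown also leave the tert-butyl group and the 4-hydroxyphenyl group the same throughout, so they say nothing about replacing either, for example the tert-butyl group with a longer chain or the hydroxyl group with a carboxylic acid.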